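The source may report more compounds than this note shows. Statements on the series, on what has been measured and on what is new or still open speak of the compounds shown alone.

In a functional assay on CHO cells for positive allosteric modulation of metabotropic glutamate receptor 2 (Homo sapiens), read by scintillation counting and GTPgammaS binding, with a stated time of 30 min (on this read-out higher numbers stand for larger maximal responses and lower numbers for smaller maximal responses), compound 3 `CC(C)CCn1ccc(-c2ccc(Oc3cccnc3)cc2)c(C#N)c1=O` gives 231%, the highest of the three numbers measured. Compound 2 `CC(C)CCn1ccc(-c2ccc(OCC3CC3)cc2)c(C#N)c1=O` gives 192% and compound 1 `COc1cccc(-c2ccn(CCC(C)C)c(=O)c2C#N)c1` gives 176%. Within the data shown here, the only step between two compounds that differ in one place, a number 39 percentage points higher from compound 2 to compound 3 (beyond the scatter), concerns the group carried on an oxygen on an aromatic ring. Compound 4 `Cc1ncccc1Oc1ccc(-c2ccn(CCC(C)C)c(=O)c2C#N)cc1` differs from compound 3 in another way: methyl in place of hydrogen on an aromatic carbon. Among the measured compounds shown here, no measured step involves a methyl in place of hydrogen on an aromatic carbon, so that earlier step offers no direct guidance. With nothing pointing either way, the change to compound 4 is expected to be a number 6 percentage points lower from compound 3 to compound 4 (within the scatter), within the usual scatter. Compound 4 is therefore estimated at 225%, in a range from 185% to 265%.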

Compound 4, largest response reached (Emax), in percent of the reference or control that the assay uses: 256%
Estimate against measurement, compound 4: 31 percentage points below, and the stated range covers the measured number.
By their numbers in this assay, from the lowest: compound 1; then compound 2; then compound 3; then compound 4.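

Methyl in place of hydrogen on an aromatic carbon, next to the ring nitrogen, is the first change shown at this position, and in this assay it gives a number 25 percentage points higher from compound 3 to compound 4 (beyond the scatter). This position therefore takes a methyl with a gain in maximal response, not a loss. Against the cyclopropylmethyl group, 2-methylpyridin-3-yl gives a number 64 percentage points higher from compound 2 to compound 4 (beyond the scatter). Nothing available explains this gain. On these data alone, whether an ethyl, a methoxy or an amine on this same carbon would raise or lower the response remains open, as does the effect of a methyl elsewhere on the pyridin-3-yl ring.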